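The source may report more compounds than this note shows. Statements on the series, on what has been measured and on what is new or still open speak of the compounds shown alone.

Compound 3 `O=C(Nc1ccc(OCc2nc3ccccc3s2)cc1)Nc1ccccc1Cl` is measured in an assay on isolated protein for inhibition of Polyunsaturated fatty acid 5-lipoxygenase (Homo sapiens), read by HPLC, with a stated time of 10 min (on this read-out lower numbers stand for stronger inhibition and higher numbers for weaker inhibition), where compound 3 gives 360 nM. Among the three compounds measured, compound 3 sits in the middle: compound 1 `Cc1cc(OCc2nc3ccccc3s2)ccc1NC(=O)Nc1ccccc1Cl` gives 830 nM, and compound 2 `Cc1cc(OCc2nc3ccccc3s2)ccc1NC(=O)Nc1cc(Cl)cc(Cl)c1` gives 80 nM, so compound 3 lies a 2.3-fold lower number from compound 1 to compound 3 (0.36 log units; beyond the scatter) from compound 1 and well above compound 2.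

Compound 4 `O=C(Nc1ccc(OCc2nc3ccccc3s2)cc1)Nc1cc(Cl)cc(Cl)c1` differs from compound 3 by one change: 3,5-dichlorophenyl in place of 2-chlorophenyl on an amide-type nitrogen. The same swap has been seen once already, on the methyl-bearing core, where it gave a 10-fold lower number from compound 1 to compound 2 (1.02 log units; beyond the scatter). A similarly large drop is therefore expected for compound 4, an estimated 10-fold lower number from compound 3 to compound 4 (1.00 log units; beyond the scatter). On that basis compound 4 is expected to give about 36 nM in this assay, most likely between 15 nM and 90 nM.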

Compound 4, half-maximal inhibitory concentration: 90 nM
For compound 4 the middle estimate is 2.5-fold (0.40 log units) below the measured one; measured number inside the range.
By their numbers in this assay, from the lowest: compounds 2 and 4 (each within the scatter of the next); then compound 3; then compound 1.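

The 3,5-dichlorophenyl group also lowers the number on the core without the methyl (a 4.0-fold lower number from compound 3 to compound 4 (0.60 log units; beyond the scatter)), so this gain at the amide-type nitrogen is not confined to one core, and its size on the two cores agrees: the same change on two cores in this assay, a 10-fold lower number (1.02 log units; beyond the scatter) from compound 1 to compound 2 and a 4.0-fold lower number (0.60 log units; beyond the scatter) from compound 3 to compound 4, 2.6-fold (0.41 log units) apart, within the scatter of two such steps. Once 3,5-dichlorophenyl is present, hydrogen in place of methyl gives no real change (a 1.1-fold higher number from compound 2 to compound 4 (0.05 log units; within the scatter)), yet this step also cannot be told apart from its counterpart on the 2-chlorophenyl compounds: the same change on two cores in this assay, a 2.3-fold lower number (0.36 log units; beyond the scatter) from compound 1 to compound 3 and a 1.1-fold higher number (0.05 log units; within the scatter) from compound 2 to compound 4, 2.6-fold (0.41 log units) apart, within the scatter of two such steps. As far as these compounds go, what a plain phenyl or a pyridine ring would give on this nitrogen stays open, as does an ethyl or methoxy group in place of the methyl.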